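A few compounds are considered here, and "the series" means these few. Any claim that something is new, unique, unknown or untested is made for them only; others in the source may bear on it.

Compounds measured so far:
Compound 1, `CCCCCCc1ccc2nc(N)sc2c1`, in a functional assay on the whole organism with Rattus norvegicus as the target (on this read-out higher numbers stand for an effect only at larger amounts of compound and lower numbers for an effect already at smaller amounts), compound 1 gives 7 mg/kg.
Compound 2, `Nc1nc2ccc(C(=O)C(F)(F)F)cc2s1`; for compound 2 only a limit is known in this assay, > 10 mg/kg, which is a limit and not a number.
Compound 3, `N=c1sc2cc(OC(F)(F)F)ccc2n1CCS(N)(=O)=O`, in this assay compound 3 gives 6 mg/kg.

Compound 3 stands at the lower of the two numbers, but compound 1 sits within the scatter of it, so the two cannot be told apart. The third compound contributes only a limit, the situation described by the limit of > 10 mg/kg in this assay, at which 1 of the 3 values shown sits.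

Compound 4, `N=c1sc2cc(OC(F)(F)F)ccc2n1CCN1CCCCC1`, has not yet been measured. It differs from compound 3 in one place: piperidin-1-yl in place of sulfamoyl on a saturated chain carbon, two bonds along the chain from an aromatic nitrogen. No measured pair among these compounds shows an exchange of this kind, so there is no step to lean on, and nothing here says which way the number should move. The expectation is therefore a step of no more than the scatter in either direction, with a wide range around it, no change at the digits printed from compound 3 to compound 4 (within the scatter). On that basis compound 4 is expected at 6 mg/kg, with a range from 2 mg/kg to 20 mg/kg.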

Compound 4, dose for half-maximal effect: 2 mg/kg
Beside the measured number, compound 4's estimate is 3.0-fold (0.48 log units) above it, and the stated range covers the measured number.
By their numbers in this assay, from the lowest: compound 4; then compounds 3 and 1 (each within the scatter of the next). At a limit, above all of these: compound 2.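

In this assay, the change at this place gives a 3.0-fold lower number from compound 3 to compound 4 (0.48 log units; beyond the scatter), and this is the first step among these compounds that can be read at all, since the earlier ones differ from one another in more than one place. It shows that the sulfamoyl group on this chain is not needed for the effect: a six-membered non-aromatic ring carrying a nitrogen can take its place, and the effect then appears at a smaller dose, though this is a single modest step on one core. Within the data shown here, nothing measured here speaks to why the number moves, as the only available evidence concerns a different compound.

From the compounds shown here alone, what remains open is which part of piperidin-1-yl matters, the ring itself or its nitrogen: a cyclohexyl ring would keep the ring without that nitrogen, while an open-chain diethylamino group would keep the nitrogen without the ring. A morpholin-4-yl ring or a longer chain between the aromatic nitrogen and the piperidine would show how far this one step can be extended.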